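A few compounds are considered here, and "the series" means these few. Any claim that something is new, unique, unknown or untested is made for them only; others in the source may bear on it.

Of the compounds shown here, three sharing one core have been measured in an assay on isolated protein for agonist activity at Bile acid receptor (Homo sapiens), read by AlphaScreen, with a stated time of 30 min; on this read-out higher numbers stand for an effect only at larger amounts of compound and lower numbers for an effect already at smaller amounts. Compound 1 `Cc1ccccc1-n1nc(C)c2c1NC(=O)[C@H](C)S[C@@H]2c1ccc(-c2ccoc2)cc1` gives 3500 nM, compound 2 `COc1ccccc1-n1nc(C)c2c1NC(=O)[C@H](C)S[C@@H]2c1ccc(Oc2ccccc2)cc1` gives 3300 nM, and compound 3 `Cc1nn(-c2ccccc2Br)c2c1C(c1ccc(Oc3ccccc3)cc1)SC(C)C(=O)N2` gives 1800 nM. Compound 2 sits in the middle of this set; its nearest neighbour is compound 1 and its furthest is compound 3, yet both gaps fall within the usual scatter, so the three read as one level in this assay.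

Compound 4 `Cc1cccc(-n2nc(C)c3c2NC(=O)[C@H](C)S[C@@H]3c2ccc(Oc3ccccc3)cc2)c1` differs from compound 2 by one change: 3-methylphenyl in place of 2-methoxyphenyl on an aromatic nitrogen. Among the compounds with values here, no measured pair isolates this change, and compound 1 carries a differently substituted aryl on the same nitrogen together with another distal group, so it gives no clean guide. The step from compound 2 to compound 4 is expected to stay within the scatter, a 1.1-fold lower number from compound 2 to compound 4 (0.04 log units; within the scatter), with no clear direction. Compound 4 is therefore estimated at 3000 nM, within a range of 1200 nM to 7500 nM.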

Compound 4, half-maximal effective concentration: 2400 nM
Estimate against measurement, compound 4: 1.3-fold (0.10 log units) above; low and high end bracket the measured number.
By their numbers in this assay, from the lowest: compounds 3, 4, 2 and 1 (each within the scatter of the next).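

Within the data shown here, on the aromatic nitrogen, the exchange of 2-methoxyphenyl for 3-methylphenyl gives the first comparison that differs in one place: in this assay the result is a 1.4-fold lower number from compound 2 to compound 4 (0.14 log units; within the scatter), which keeps both compounds at one level. The aryl group on this nitrogen can therefore lose its hydrogen-bond acceptor and change its substituent without a step beyond the scatter in this pair. No available data explain this result.

Going by these compounds, it remains open whether a carboxylic acid or an amine on this aryl group, or a pyridine ring in its place, would move the number beyond the scatter.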